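This account rests on a few compounds, and the source may have more. Where it says the series, first, only, none or still open, it means among the compounds named here.

Among the compounds with values here, compound 1 `CONC(=O)[C@@H]1CC=C(CCC=C(C)C)C[C@H]1c1ccccc1` carries a methoxycarbamoyl group on the shared core; in an assay on isolated protein for inhibition of Apoptosis regulator Bcl-2 (Homo sapiens), read by fluorescence polarization, with stated times of 5 min and 10 min (on this read-out lower numbers stand for stronger inhibition and higher numbers for weaker inhibition), compound 1 gives 2700 nM, one of only two numbers in the set. Compound 2 `COC(=O)CCNC(=O)[C@H]1CC=C(CCC=C(C)C)C[C@@H]1c1ccccc1` gives 3100 nM, a gap to compound 1 within the scatter. Compound 3 `CC(C)=CCCC1=CC[C@H](C(=O)Nc2ccc(O)cc2)[C@@H](c2ccccc2)C1` returns only a limit of the assay, > 23000 nM. Within the data shown here, the single measured step, an at least 7.4-fold higher number from compound 2 to compound 3 (0.87 log units; beyond the scatter), ends at the limit of > 23000 nM in this assay, at which 1 of the 3 values shown sits, and concerns the substituent on the amide-type nitrogen, not the oxygen. Compound 4 `CC(C)=CCCC1=CC[C@@H](C(=O)NO)[C@H](c2ccccc2)C1` differs from compound 1 by hydrogen in place of methyl on an oxygen. Among the measured compounds shown here, no measured step touches that oxygen, so the expectation rests on the change alone: a step of a 1.1-fold higher number from compound 1 to compound 4 (0.05 log units; within the scatter) in this assay is expected, not beyond the scatter. Compound 4 is estimated at 3000 nM, between 1000 nM and 9000 nM.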

Compound 4, inhibition constant: 700 nM
The estimate for compound 4 lay 4.3-fold (0.63 log units) above the measured number; measured number outside the range, below it.
By their numbers in this assay, from the lowest: compound 4; then compounds 1 and 2 (each within the scatter of the next). At a limit, above all of these: compound 3.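

Hydrogen in place of methyl on this oxygen gives a 3.9-fold lower number from compound 1 to compound 4 (0.59 log units; beyond the scatter) in this assay, so the oxygen, which no earlier step touched, is a place where the number responds to the loss of one carbon. Within the data shown here, the only earlier step ran toward a higher number, on the amide-type nitrogen; this is the first to run toward a lower one. Nothing at hand bears on why the number falls. As far as these compounds go, whether ethoxy in place of methoxy, or a carboxylic acid or a primary amide in place of hydroxycarbamoyl, keeps this lower number stays open.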